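Benzyl-for-ethyl ester exchange in a phenolic diene series

The compounds below may be only part of what the source reports. "The series", "measured", "known", "first", "only" and "open" are said of these compounds alone.

Measured compounds in a functional assay on HepG2 cells (Homo sapiens) for cytotoxicity, with a stated time of 72 h; a higher number here means that more compound is needed for the effect, a lower number that less compound is needed:
- compound 1 `C=C[C@@](C)(/C=C/c1ccc(O)cc1)CC/C=C(C)/C=C/C(=O)OCC`: the value stands at the limit of the assay, > 52000 nM.
- compound 2 `C=C[C@@](C)(/C=C/c1ccc(O)cc1)CC/C=C(C)/C=C/C(=O)OCc1ccccc1`: the value is again a limit, > 52000 nM.
- compound 3 `C=C[C@@](C)(/C=C/c1ccc(O)c(/C=C/C(=O)OCC)c1)CCC=C(C)C`: the value is likewise only a limit, > 52000 nM.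

Compound 1 and compound 2 share one core and differ by phenyl in place of methyl on a saturated chain carbon bound to an oxygen next to a carbonyl group. The step this made, a step that the two limits leave unreadable from compound 1 to compound 2, cannot be read because of the limit of > 52000 nM in this assay, at which 3 of the 3 values shown sit.

Compound 3 carries the ester on a different part of the molecule; the difference between the core of compound 1 and the core of compound 3 is not broken down here.

Compound 4 `C=C[C@@](C)(/C=C/c1ccc(O)c(/C=C/C(=O)OCc2ccccc2)c1)CCC=C(C)C` is not yet measured. It differs from compound 3 by phenyl in place of methyl on a saturated chain carbon bound to an oxygen next to a carbonyl group, the same change as from compound 1 to compound 2, at the same kind of place.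

For compound 4 in this assay the expected step of a number no higher from compound 3 to compound 4 (the limit leaves the size open) is small, since all three measured values sit at the limit and the earlier step left no readable size. The estimate for compound 4 is 52000 nM, with a range from 25000 nM to 150000 nM, most likely reported as a limit again.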

Compound 4, half-maximal effective concentration: > 52000 nM
Compound 4: only a limit was reported; the forecaster's own chance of this, stated with the estimate: 85%; the middle value lies on the limit itself.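

No step can be read from compound 3 to compound 4 in this assay, because the exchange of ethyl for benzyl meets the same reading as before: the limit of > 52000 nM in this assay, at which 4 of the 4 values shown sit.

The compounds shown leave open whether any of them has a measurable effect on these cells, and whether the ester exchange alters that effect on either core.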